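Three analogues at the assay ceiling, a fourth still untested

A few compounds are considered here, and "the series" means these few. Any claim that something is new, unique, unknown or untested is made for them only; others in the source may bear on it.

Compound 2 `CSc1nnc(C)n1N1C(=O)c2ccccc2C1=O`, compound 1 `CCOC(=O)CSc1nnc(C)n1N1C(=O)c2ccccc2C1=O` and compound 3 `CCc1nnc(SC)n1N1C(=O)c2ccccc2C1=O` were examined in a functional assay on HepG2 cells (Homo sapiens) for cytotoxicity, read by MTT assay, with a stated time of 48 h; a lower number here means a stronger inhibitor, a higher number a weaker inhibitor. In this assay compound 2 gives > 200000 nM, a limit of the assay rather than a number. Compound 1 likewise returns only the limit > 200000 nM. Compound 3 also reaches only the limit > 200000 nM. The step that the two limits leave unreadable from compound 2 to compound 1 therefore cannot be read, nor can a step that the two limits leave unreadable from compound 2 to compound 3, since every value sits at the limit of > 200000 nM in this assay, at which 3 of the 3 values shown sit.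

Compound 4 `CCOC(=O)CSc1nnc(CC)n1N1C(=O)c2ccccc2C1=O` remains unmeasured. It differs from compound 3 by ethoxycarbonyl in place of hydrogen on a saturated chain carbon bound to a sulfur, the same change as that from compound 2 to compound 1, (ethoxycarbonyl in place of hydrogen on a saturated chain carbon bound to a sulfur). The two cores differ by methyl in place of hydrogen on a saturated chain carbon bound to an aromatic carbon. Since compound 1 stayed at the limit of > 200000 nM in this assay, at which 3 of the 3 values shown sit, after that change, compound 4 is expected to stay at the limit as well, an estimated step that the limit leaves unreadable from compound 3 to compound 4 in this assay. Compound 4 is estimated at 300000 nM, expected between 150000 nM and 1000000 nM.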

Compound 4, half-maximal inhibitory concentration: > 200000 nM
Compound 4 was reported as a limit; the forecaster's own chance of this, stated with the estimate: 90%; the middle value is on the limit's open side.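

Compound 4 also returns only a limit, so neither the step from compound 3 to compound 4 nor the step from compound 1 to compound 4 can be read. Which structure, if any, gives a readable value in this assay stays open among the compounds shown.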